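Swapping Chloro for Cyano on the Benzyl Arm

A few compounds are considered here, and "the series" means these few. Any claim that something is new, unique, unknown or untested is made for them only; others in the source may bear on it.

Within the data shown here, in a functional assay on A549 cells (Homo sapiens) for cytotoxicity, read by MTT assay, with a stated time of 48 h (on this read-out higher numbers stand for weaker inhibition and lower numbers for stronger inhibition), compound 3 `O=c1ccoc2cc(OCc3cn(Cc4cccc(Cl)c4)nn3)ccc12` gives 13700 nM, the only actual number among the three measured compounds. Compound 1 `O=c1ccoc2cc(OCc3cn(Cc4ccc(Cl)cc4)nn3)ccc12` reaches only the limit > 100000 nM in this assay. Compound 2 `O=c1ccoc2cc(OCc3cn(Cc4ccccc4)nn3)ccc12` likewise gives only the limit > 100000 nM. Because of the limit of > 100000 nM in this assay, at which 2 of the 3 values shown sit, one step stays unreadable: a step that the two limits leave unreadable from compound 1 to compound 2. Two steps do read: an at least 7.2-fold lower number from compound 1 to compound 3 (0.86 log units; beyond the scatter), and an at least 7.2-fold lower number from compound 2 to compound 3 (0.86 log units; beyond the scatter). Compound 4 `N#Cc1cccc(Cn2cc(COc3ccc4c(=O)ccoc4c3)nn2)c1` differs from compound 3 by cyano in place of chloro on an aromatic carbon. Among the measured compounds shown here, no measured step covers cyano. The step from compound 2 to compound 3 shows that chloro on that carbon can lower the number, and the step from compound 1 to compound 3 shows that where the chloro sits matters, but neither tells how cyano compares with chloro, so the expectation rests on compound 3 alone with wide uncertainty. The estimate for compound 4 is 30000 nM, with a range from 8000 nM to 100000 nM. This corresponds to an expected step of a 2.2-fold higher number from compound 3 to compound 4 (0.34 log units; beyond the scatter), a mild weakening that could reach the limit.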

Compound 4, half-maximal inhibitory concentration: 14300 nM
Estimate against measurement, compound 4: 2.1-fold (0.32 log units) above; the range from low to high includes it.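

In this assay the change from 3-chlorobenzyl to 3-cyanobenzyl is a 1.0-fold higher number from compound 3 to compound 4 (0.02 log units; within the scatter) and so leaves no readable difference between chloro and nitrile on this carbon. Against the benzyl arm without a substituent, the nitrile gives an at least 6.9-fold lower number from compound 2 to compound 4 (0.84 log units; beyond the scatter) and, against the 4-chlorophenyl arm, it gives an at least 6.9-fold lower number from compound 1 to compound 4 (0.84 log units; beyond the scatter) so the lower number at this place is no longer tied to chloro alone. Both of these steps start from a limit and show only a smallest possible size: the limit of > 100000 nM in this assay, at which 2 of the 4 values shown sit.

From the compounds shown here alone, whether an amine, a carboxylic acid or a methoxy group on this carbon would also give a lower number than hydrogen remains open. So does whether a nitrile on the carbon that carries chloro in compound 1 would stay at the limit as that compound does.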